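This account rests on a few compounds, and the source may have more. Where it says the series, first, only, none or still open, it means among the compounds named here.

In an assay for inhibition of histone-lysine N-methyltransferase, H3 lysine-79 specific (Homo sapiens), read by scintillation counting, with stated times of 15 min and 60 min, tested at 100 uM, in the presence of a further agent that is not named here (on this read-out higher numbers stand for a stronger effect at the one concentration tested and lower numbers for a weaker effect), two compounds have been measured so far. Compound 1 `Fc1cccc(-c2nnc3sc(/C=C/c4ccco4)nn23)c1` gives 29%, and compound 2 `Cc1occc1-c1nnc2sc(CCc3ccccc3)nn12` gives 27%; the two numbers lie within the usual scatter of each other, so neither stands apart, although the number of compound 1 is the one at the top of this small set. Compound 3 `Cc1cccc(-c2nnc3sc(/C=C/c4ccco4)nn23)c1` remains to be measured. It differs from compound 1 by methyl in place of fluoro on an aromatic carbon. No comparable change has been measured here, so the step is expected to be small: from compound 1 to compound 3 it is estimated as a number 1 percentage points higher from compound 1 to compound 3 (within the scatter), within the scatter, because compound 1 gives 29% with a single heavy atom exchanged. Compound 3 is therefore expected to give about 30%, between 15% and 45%.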

Compound 3, a percentage reported as inhibition, at one concentration (the size of the read-out at that concentration, not a potency): 74%
Compound 3: the middle estimate sits 44 percentage points below what was measured; the measured number lies above the stated range.
By their numbers in this assay, from the lowest: compounds 2 and 1 (each within the scatter of the next); then compound 3.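

Going from 3-fluorophenyl to 3-methylphenyl in this assay gives a step of a number 45 percentage points higher from compound 1 to compound 3 (beyond the scatter) and shows that exchanging a single heavy atom at this aromatic carbon can change the read-out strongly. Among the compounds shown here, it is the first step between compounds differing in one place here, and the rest of compound 1 stays unchanged in compound 3. Nothing available explains the size of this step. As far as these compounds go, it remains open whether ethyl, methoxy or an amine at this carbon would match methyl. From the compounds shown here alone, whether the same exchange would have a similar effect on another core also remains open.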